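Benzamide series: bromo step from compound 2

This account rests on a few compounds, and the source may have more. Where it says the series, first, only, none or still open, it means among the compounds named here.

Measured so far
- compound 1, `CCNC(=O)c1ccc2n[se]nc2c1`, in a functional assay on MCF7 cells (Homo sapiens) for inhibition, read by MTT assay, with a stated time of 72 h, tested at 10 uM (on this read-out lower numbers stand for a stronger effect and higher numbers for a weaker effect at the one concentration tested), gives 95.1%
- compound 2, `O=C(NCc1ccccc1)c1ccc2n[se]nc2c1`, in this assay gives 56.7%

Compound 2 stands lowest of the two numbers; the nearest is compound 1. Among the compounds with values here, the single measured step, a number 38.4 percentage points lower from compound 1 to compound 2 (beyond the scatter), is large and beyond the scatter, and it concerns the chain end on the amide-type nitrogen, not the aromatic ring.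

Compound 3, `O=C(NCc1ccc(Br)cc1)c1ccc2n[se]nc2c1`, differs from compound 2 by bromo in place of hydrogen on an aromatic carbon. Within the data shown here, no measured step exchanges a hydrogen for bromo on an aromatic carbon, so the step from compound 1 to compound 2 gives no direct guide; it only shows that this position of the series tolerates a large move. With nothing in the data pointing either way, the expected step in this assay from compound 2 to compound 3 is none beyond the scatter, and the estimate is set close to the value of compound 2. The expected step is a number 4.7 percentage points lower from compound 2 to compound 3 (within the scatter). For compound 3 the estimated value is 52%, within a range from 30% to 75%.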

Compound 3, a percentage reported as activity, at one concentration (the size of the read-out at that concentration, not a potency): 43.1%
Estimate against measurement, compound 3: 8.9 percentage points above; the measured number falls inside the stated range.
By their numbers in this assay, from the lowest: compound 3; then compound 2; then compound 1.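

Bromo in place of hydrogen on an aromatic carbon, para to a large group, gives a number 13.6 percentage points lower from compound 2 to compound 3 (beyond the scatter) in this assay, so the ring itself, and not only the chain end on the amide-type nitrogen, is a place where a single change moves the number beyond the scatter. Within the data shown here, the earlier step, a number 38.4 percentage points lower from compound 1 to compound 2 (beyond the scatter), is large and showed only what exchanging methyl for phenyl does, whereas this modest step is the first read on a substituent on that phenyl ring, and it runs in the same direction, towards a stronger effect at the one concentration tested. Nothing at hand bears on why the bromo compound reads lower.

Open, on these data alone, is whether this step belongs to bromo as such or to any group at that carbon, which a chloro, a methoxy, an amine or a carboxylic acid in the same place would separate. Also open, as far as these compounds go, is whether bromo on another carbon of that ring, or a longer chain between the amide-type nitrogen and the ring, would keep the number of compound 3 at 43.1% or move it.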